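Isopropyl to cyclopropyl on the carbinol carbon

The source may report more compounds than this note shows. Statements on the series, on what has been measured and on what is new or still open speak of the compounds shown alone.

Compound 1 `CC(=O)Nc1cccc(-c2ccc(C(O)(c3c[nH]cn3)C(C)C)cc2)c1` is the racemic carbinol of the series. In an assay on isolated protein for inhibition of steroid 17-alpha-hydroxylase/17,20 lyase (Homo sapiens) (a higher number here means a weaker inhibitor, a lower number a stronger inhibitor), compound 1 gives 24 nM. Its single enantiomer, compound 2 `CC(=O)Nc1cccc(-c2ccc([C@](O)(c3c[nH]cn3)C(C)C)cc2)c1`, gives 26 nM in this assay, and the step of a 1.1-fold higher number from compound 1 to compound 2 (0.03 log units; within the scatter) places the two within the scatter of each other; the only distinction between them is the fact that one of compounds 1 and 2 is drawn with a defined configuration and the other without, at the place where they differ.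

Compound 3 `CC(=O)Nc1cccc(-c2ccc(C(O)(c3c[nH]cn3)C3CC3)cc2)c1` is not yet measured. It differs from compound 1 by cyclopropyl in place of isopropyl on a saturated chain carbon bound to two aromatic carbons and an oxygen on a saturated carbon. Among the compounds with values here, no measured step touches that carbon: the sole step on record, from compound 1 to compound 2, concerns the drawn configuration and not the substituent, and it was within the scatter. The change exchanges one three-carbon group for another without ring, donor, acceptor or charge being gained or lost beyond the small ring itself, so no step beyond the scatter is expected in this assay. Compound 3 is accordingly expected to give 28 nM, with a range from 10 nM to 80 nM. The expected step of a 1.2-fold higher number from compound 1 to compound 3 (0.07 log units; within the scatter) is therefore essentially flat.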

Compound 3, half-maximal inhibitory concentration: 45 nM
For compound 3 the middle estimate is 1.6-fold (0.21 log units) below the measured one, and the stated range covers the measured number.
By their numbers in this assay, from the lowest: compounds 1, 2 and 3 (each within the scatter of the next).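

In this assay, within the data shown here, this is the first substituent exchange on record at the saturated chain carbon, and it stays within the scatter (a 1.9-fold higher number from compound 1 to compound 3 (0.27 log units; within the scatter)). Isopropyl and cyclopropyl, each of 3 heavy atoms, therefore cannot be told apart here, so the one three-membered non-aromatic ring of carbon only that enters carries no readable penalty or gain at this place. Nothing on record offers a cause for this step.

Going by these compounds, it remains open whether a larger group at this carbon, such as cyclobutyl, phenyl or a longer chain, or one bearing an amine or a carboxylic acid, would move the number beyond the scatter. On these data alone, compound 3 is drawn without a configuration, so what its separate enantiomers would give also stays open.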